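Pyrrolidine nitrogen substituent removal in the shared core

The source may hold more compounds than are shown below. What is called first, only, known or untested is meant among the compounds shown, and "the series" means these compounds.

Measured compounds in a functional assay on HCC827 cells (Homo sapiens) for antiproliferative activity, read by MTT assay, with a stated time of 72 h; on this read-out lower numbers stand for stronger inhibition and higher numbers for weaker inhibition:
compound 1 `CNC(=O)CN1CC[C@H](n2c(Nc3ccccc3)nc3cnc(Nc4ccc(N5CCN(C)CC5)cc4)nc32)C1`: 170 nM
compound 2 `CN1CCN(c2ccc(Nc3ncc4nc(Nc5ccc(F)cc5)n([C@@H]5CCN(C(=O)OC(C)(C)C)C5)c4n3)cc2)CC1`: 27 nM
compound 3 `CC(=O)Nc1cccc(-n2c(Nc3ccc(F)cc3)nc3cnc(Nc4ccc(N5CCN(C)CC5)cc4)nc32)c1`: 10 nM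

Compound 1 gives the highest number of the three; compound 2 and compound 3 both sit well below it. Within the data shown here, the only measured step, a 2.7-fold lower number from compound 2 to compound 3 (0.43 log units; beyond the scatter), swaps the substituent on the aromatic nitrogen, but neither partner carries the group that compound 1 does, and compound 1 also differs from both in the anilino group. Compound 4 `CN1CCN(c2ccc(Nc3ncc4nc(Nc5ccccc5)n([C@@H]5CCNC5)c4n3)cc2)CC1` differs from compound 1 in one place: pyrrolidin-3-yl in place of 1-((methylcarbamoyl)methyl)pyrrolidin-3-yl on an aromatic nitrogen. Among the measured compounds shown here, no measured pair reports this change, so it can only be taken as uncharted; a step of no more than modest size in either direction is expected, with a 1.4-fold lower number from compound 1 to compound 4 (0.15 log units; within the scatter) as the working guess. Compound 4 is therefore estimated at 120 nM, range 40 nM to 400 nM.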

Compound 4, half-maximal inhibitory concentration: 65 nM
The estimate for compound 4 lay 1.8-fold (0.27 log units) above the measured number, and the stated range covers the measured number.
By their numbers in this assay, from the lowest: compound 3; then compound 2; then compound 4; then compound 1.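

Among these compounds, this is the first direct pair at this position, on an aromatic nitrogen of the shared core, and it gives a 2.6-fold lower number from compound 1 to compound 4 (0.42 log units; beyond the scatter) with the anilino group unchanged. The 1-((methylcarbamoyl)methyl)pyrrolidin-3-yl group is therefore not required for activity in this pair, and the free pyrrolidin-3-yl compound gives the lower number. No measured evidence bears on the cause of this step. Going by these compounds, how a methyl, an acetyl or a longer chain ending in a carboxylic acid on the pyrrolidine nitrogen would compare remains open, as does whether the step holds with the fluorine-bearing anilino group of compound 2.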